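Working notes: changing the side group of compound 1

The source may report more compounds than this note shows. Statements on the series, on what has been measured and on what is new or still open speak of the compounds shown alone.

Measured in a physicochemical assay for solubility, at pH 7.4; a lower number here means a less soluble compound, a higher number a more soluble compound:
- compound 1 `CNC1CN(c2c(F)cc3c(=O)c(C(=O)O)cn(C4CC4)c3c2F)C1`: 1.7 ug/mL
- compound 2 `C[C@H]1[C@H](N)CN1c1c(F)c(N)c2c(=O)c(C(=O)O)cn(C3CC3)c2c1F`: 37.7 ug/mL
- compound 3 `C[C@@H]1[C@@H](N(C)C)CN1c1cc2c(cc1F)c(=O)c(C(=O)O)cn2C1CC1`: 96.3 ug/mL

Compound 1 stands lowest of the three, and compounds 2 and 3 both lie beyond the scatter above it. Compound 4 `C[C@H]1[C@@H](N)CN1c1c(F)cc2c(=O)c(C(=O)O)cn(C3CC3)c2c1F` remains unmeasured. It has the same atoms as compound 1, joined differently, with the change on an aromatic carbon of the shared core: a group of 6 heavy atoms (4 carbon, 2 nitrogen; one four-membered non-aromatic ring with 1 hetero atom) in place of a group of 6 heavy atoms (4 carbon, 2 nitrogen; one four-membered non-aromatic ring with 1 hetero atom), on an aromatic carbon. The 3-(methylamino)azetidin-1-yl group leaves, and the entering group has defined stereocentres.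

Among the measured compounds shown here, no pair of measured compounds differs in one place only, so the evidence is indirect. Compound 2, at 37.7 ug/mL, and compound 3, at 96.3 ug/mL, also have defined stereocentres, but both differ from compound 1 elsewhere as well. A moderate upward step beyond the scatter is expected, smaller than the gaps from compound 1 to compounds 2 and 3. The expected change is a 7.1-fold higher number from compound 1 to compound 4 (0.85 log units; beyond the scatter). Compound 4 is estimated at 12 ug/mL, with an expected range of 3 ug/mL to 50 ug/mL.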

Compound 4, solubility: 23.6 ug/mL
Beside the measured number, compound 4's estimate is 2.0-fold (0.29 log units) below it; the measured number falls inside the stated range.
By their numbers in this assay, from the lowest: compound 1; then compounds 4 and 2 (each within the scatter of the next); then compound 3.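

Among the compounds shown here, this is the first comparison that differs in one place only: in this assay, the step is a 14-fold higher number from compound 1 to compound 4 (1.14 log units; beyond the scatter), at the aromatic carbon ortho to two fluoro groups. The 3-(methylamino)azetidin-1-yl group and the entering group have the same heavy atoms, ring size, hydrogen-bond donor and acceptor counts and lack of net charge, so the step goes with how the atoms are joined and not with any of those counts, and the entering group also has 2 defined stereocentres. No measurement in hand accounts for the step.

Whether the stereocentres matter stays open, since no other stereo form of the entering group is shown in a one-place pair. Going by these compounds, how a piperazine ring or an open-chain amine at this aromatic carbon would read in this assay also stays open.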